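The source may hold more compounds than are shown below. What is called first, only, known or untested is meant among the compounds shown, and "the series" means these compounds.

Working notes on the series, read in a functional assay on T-24 cells (Homo sapiens) for antiproliferative activity, read by MTT assay, with a stated time of 48 h; a higher number here means a weaker inhibitor, a lower number a stronger inhibitor. Compound 1 `O=C(Nc1ccc(Cl)cc1)Nc1cccc(CNc2nccnc2Cl)c1` gives 5470 nM, compound 2 `Cc1ccccc1NC(=O)Nc1cccc(CNc2nccnc2Cl)c1` gives 13600 nM and compound 3 `CC(C)(C)c1ccc(NC(=O)Nc2cccc(CNc3nccnc3Cl)c2)cc1` gives 6010 nM. Compound 3 stands level with compound 1, and both numbers lie under that of compound 2. Compound 4 `Cc1ccc(NC(=O)Nc2cccc(CNc3nccnc3Cl)c2)cc1` differs from compound 3 by methyl in place of tert-butyl on an aromatic carbon. The closest measured change is a 1.1-fold higher number from compound 1 to compound 3 (0.04 log units; within the scatter), with tert-butyl in place of chloro, and it stays within the scatter. The modest step of a 2.5-fold higher number from compound 1 to compound 2 (0.40 log units; beyond the scatter), with 2-methylphenyl in place of 4-chlorophenyl, is a different exchange and bears less directly. No step beyond the scatter is therefore expected in this assay. The estimated change is a 1.1-fold higher number from compound 3 to compound 4 (0.03 log units; within the scatter). For compound 4 the expected value is 6500 nM, with an estimated range from 3500 nM to 12000 nM.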

Compound 4, half-maximal inhibitory concentration: 9820 nM
Compound 4: middle estimate off by 1.5-fold (0.18 log units), on the low side; measured number inside the range.
By their numbers in this assay, from the lowest: compounds 1, 3, 4 and 2 (each within the scatter of the next, the first and the last beyond it).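

In this assay, the aromatic carbon para to a large group accepts methyl with no step beyond the scatter: tert-butyl to methyl gives a 1.6-fold higher number from compound 3 to compound 4 (0.21 log units; within the scatter) and chloro to methyl gives a 1.8-fold higher number from compound 1 to compound 4 (0.25 log units; within the scatter), so these three groups are not told apart here. Compound 4 also separates the place of the methyl from the change of group that compound 2 combined, and 4-methylphenyl in place of 2-methylphenyl gives a 1.4-fold lower number from compound 2 to compound 4 (0.14 log units; within the scatter), again within the scatter. Nothing at hand explains these steps. From the compounds shown here alone, whether an amine or a carboxylic acid on this carbon would move the number beyond the scatter from compound 4 remains open.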